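A Nitro Group in Place of a Ring Hydrogen

The compounds below may be only part of what the source reports. "The series", "measured", "known", "first", "only" and "open" are said of these compounds alone.

Two compounds have so far been measured in a functional assay on NCI-H460 cells (Homo sapiens) for inhibition, read by MTT assay, with a stated time of 24 h, tested at 1 ug/mL; a higher number here means more inhibition of growth at the concentration tested, a lower number less inhibition of growth:

Compound 1 `O=C(CCCCC(S)CCS)Nc1ccccc1` gives 4.3%.
Compound 2 `O=C(CCCCC(S)CCS)Nc1cccc(Cl)c1` gives 7.2%.

Compound 1 has the lower of the two numbers, and the gap to compound 2 is small: a number 2.9 percentage points higher from compound 1 to compound 2 (within the scatter). Among the measured compounds shown here, that single step, a chloro substituent entering on the aromatic ring of the shared core, is the only comparison available, and it lies within the usual scatter of this kind of measurement, so neither compound can be called more active than the other.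

Compound 3 `O=C(CCCCC(S)CCS)Nc1ccc([N+](=O)[O-])cc1` has not yet been measured. It differs from compound 1 in one place: nitro in place of hydrogen on an aromatic carbon. For the measured compounds named here, the only measured step that bears on this change is the one from compound 1 to compound 2, where a different group entered the same ring and produced no change beyond the scatter. On that basis, no step beyond the scatter is expected in this assay for the nitro variant either; the estimated step is a number 1.7 percentage points higher from compound 1 to compound 3 (within the scatter). Compound 3 is therefore expected to give about 6%, within a range from -6% to 18%.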

Compound 3, percent growth inhibition at one concentration: 4.64%
For compound 3 the middle estimate is 1.4 percentage points above the measured one; the range from low to high includes it.
By their numbers in this assay, from the lowest: compounds 1, 3 and 2 (each within the scatter of the next).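

In this assay, placing a nitro group on an aromatic carbon para to a large group gives a number 0.3 percentage points higher from compound 1 to compound 3 (within the scatter) and so does not separate the two compounds. Among the compounds shown here, this extends the picture from the single chloro step to a larger substituent of three heavy atoms, with two hydrogen-bond acceptors and no hydrogen-bond donors, yet the growth-inhibition number of compound 3 still cannot be told apart from that of compound 1. Nothing measured here offers an explanation for this result.

The compounds shown leave open whether a different kind of group at this same ring position, such as an amine or a carboxylic acid, would give a step beyond the scatter. They also leave open whether changing another part of the shared core, for example using a longer chain between the amide carbonyl and the sulfur-bearing carbons, would move the number more than either ring substitution has done so far.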